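The source may report more compounds than this note shows. Statements on the series, on what has been measured and on what is new or still open speak of the compounds shown alone.

In a functional assay with Oryctolagus cuniculus as the target (on this read-out lower numbers stand for stronger inhibition and higher numbers for weaker inhibition), compound 1 `COc1ccc(-c2nc(/N=C(\N)N3CCOCC3)sc2-c2ccc(OC)cc2)cc1` gives < 1000 nM, and this is a limit of the assay, not a number. For the measured compounds named here, compound 2 `COc1ccc(-c2nc(CN(C)C)sc2-c2ccc(OC)cc2)cc1` reads 96 nM, the only true number so far, so it cannot yet be ranked against a second value. The next analogue, compound 3 `COc1ccc(-c2nc(CNC(C)=O)sc2-c2ccc(OC)cc2)cc1`, carries acetamido in place of dimethylamino on a saturated chain carbon bound to an aromatic carbon. Going by the values given here, the only measured step is a step that the limit leaves unreadable from compound 1 to compound 2, which changes a different group on the aromatic carbon and gives no usable size. The expectation therefore rests on compound 2 at 96 nM, with no measured guide to direction, and the range is kept wide. The expected change is a 1.8-fold higher number from compound 2 to compound 3 (0.25 log units; within the scatter), tentatively towards weaker inhibition in this assay. Compound 3 is expected at 170 nM, with an estimated range of 30 nM to 900 nM.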

Compound 3, half-maximal inhibitory concentration: 15 nM
Compound 3: middle estimate off by 11-fold (1.05 log units), on the high side; measured number outside the range, below it.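

In this assay, for the compounds shown here, acetamido in place of dimethylamino on a saturated chain carbon bound to an aromatic carbon gives a 6.4-fold lower number from compound 2 to compound 3 (0.81 log units; beyond the scatter), the first readable step, and it lies beyond the scatter. The position therefore responds to the group it carries, and the dimethylamino group of compound 2 is not needed for activity at this level, since the amide of compound 3 reads lower. The steps from compound 1 to the other two cannot be read, because its value is a limit and not a number: the limit of < 1000 nM in this assay, at which 1 of the 3 values shown sits.

This single pair does not separate the part played by the amide hydrogen from that of the carbonyl. A primary amine or a longer acyl chain such as propionamido at this place would show how far the trend extends.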